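From a Large Aryl Group to a Small Alcohol

The source may report more compounds than this note shows. Statements on the series, on what has been measured and on what is new or still open speak of the compounds shown alone.

Compound 1 `Cc1ccc(-n2cc(-c3ccc(C)c(C(F)(F)F)c3)nn2)cc1Nc1nccc(-c2cccnc2)n1` in a functional assay on KG-1a cells (Homo sapiens) for inhibition, read by MTT assay, with a stated time of 72 h (a lower number here means a stronger inhibitor, a higher number a weaker inhibitor), gives > 30000 nM, which is a limit of the assay, not a number. Among the compounds with values here, compound 2 `COc1ccc(-c2cn(-c3ccc(C)c(Nc4nccc(-c5cccnc5)n4)c3)nn2)cc1C(F)(F)F` gives 30000 nM in this assay, the only number among the two values shown. The step of a number no higher from compound 1 to compound 2 (the limit leaves the size open) exchanges methyl for methoxy on an aromatic carbon. Compound 1 stands at the limit of > 30000 nM in this assay, at which 1 of the 2 values shown sits. Compound 3 `Cc1ccc(-n2cc(C(C)O)nn2)cc1Nc1nccc(-c2cccnc2)n1` differs from compound 2 by 1-hydroxyethyl in place of 4-methoxy-3-(trifluoromethyl)phenyl on an aromatic carbon. Within the data shown here, no measured step touches this place on the five-membered ring, so the direction and size of the change in this assay remain open. Compound 3 is expected to give 30000 nM, within 5000 nM to 100000 nM, which means the step of no change at the digits printed from compound 2 to compound 3 (within the scatter) in this assay.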

Compound 3, half-maximal inhibitory concentration: 12700 nM
Beside the measured number, compound 3's estimate is 2.4-fold (0.37 log units) above it; low and high end bracket the measured number.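

At this place on the five-membered ring, 1-hydroxyethyl in place of 4-methoxy-3-(trifluoromethyl)phenyl gives a 2.4-fold lower number from compound 2 to compound 3 (0.37 log units; beyond the scatter) in this assay, so a six-membered aromatic ring is not needed here for a readable number. Exchanging the 4-methyl-3-(trifluoromethyl)phenyl group for 1-hydroxyethyl gives an at least 2.3-fold lower number from compound 1 to compound 3 (0.37 log units; beyond the scatter). Compound 1 sits at a limit of the assay, not a number: the limit of > 30000 nM in this assay, at which 1 of the 3 values shown sits.

As far as these compounds go, how an amine, a carboxylic acid or a longer chain at this place would compare stays open. The compounds shown also cannot tell why the number falls.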